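This account rests on a few compounds, and the source may have more. Where it says the series, first, only, none or still open, it means among the compounds named here.

Working notes on the series. Compound 1 `O=C1/C(=C\c2cccc(Oc3ccccc3)c2)c2ccccc2N1c1c(Cl)cccc1Cl` carries a 3-phenoxyphenyl group on the shared core, and in a functional assay on L132 cells (Homo sapiens) for cytotoxicity, read by MTT assay, with a stated time of 72 h (a lower number here means that less compound is needed, a higher number that more compound is needed for the effect), compound 1 gives 24 ug/mL. Compound 2 `COc1ccc(/C=C2\C(=O)N(c3c(Cl)cccc3Cl)c3ccccc32)cc1` carries a 4-methoxyphenyl group instead. In this assay compound 2 gives only a limit, > 100 ug/mL, so no number stands for it. Compound 2 therefore sits at the limit of > 100 ug/mL in this assay, at which 1 of the 2 values shown sits.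

Compound 3 `O=C1/C(=C\c2cccc(Br)c2)c2ccccc2N1c1c(Cl)cccc1Cl` is not yet measured in this assay. It differs from compound 2 by 3-bromophenyl in place of 4-methoxyphenyl on a double-bonded chain carbon bound to a double-bonded ring carbon. Within the data shown here, no measured pair in the set differs in a single place, so no measured step is available as a guide, and the position of compound 2 is known only as a limit. Since compound 1 with a 3-phenoxyphenyl group gives 24 ug/mL, compound 3 is expected to fall to a number inside the measured range. The expected step is an at least 2.5-fold lower number from compound 2 to compound 3 (0.39 log units; beyond the scatter), downward and beyond the scatter. Compound 3 is estimated at 40 ug/mL, between 15 ug/mL and 100 ug/mL.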

Compound 3, concentration for half-maximal effect: 19 ug/mL
Compound 3: the middle estimate sits 2.1-fold (0.32 log units) above what was measured, within the range that was stated.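

In this assay, 3-bromophenyl in place of 4-methoxyphenyl on a double-bonded chain carbon bound to a double-bonded ring carbon gives an at least 5.2-fold lower number from compound 2 to compound 3 (0.72 log units; beyond the scatter), a step that brings this place into the measured range. Going by these compounds, the full size of this step stays unknown because one end of it is only a limit: the limit of > 100 ug/mL in this assay, at which 1 of the 3 values shown sits. Bromo in place of phenoxy on an aromatic carbon gives a 1.3-fold lower number from compound 1 to compound 3 (0.10 log units; within the scatter), so a phenoxy group is not required for a measured number here, and the two groups cannot be told apart in this read-out.

In the step from 4-methoxyphenyl to 3-bromophenyl, the group and its place on the aromatic ring change together, and the compounds shown do not separate the two. Also open, on these data alone, is how an amine or a carboxylic acid at this place would read in this assay.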